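A few compounds are considered here, and "the series" means these few. Any claim that something is new, unique, unknown or untested is made for them only; others in the source may bear on it.

In a functional assay on A549 cells (Homo sapiens) for cytotoxicity, read by colorimetric assay and MTT assay (a higher number here means a weaker inhibitor, a lower number a stronger inhibitor), compound 1 (`COc1cccc2cc(-c3ccccc3)c(O)nc12`) gives 10000 nM. Compound 2 (`COc1ccc2cc(-c3ccccc3)c(O)nc2c1`) gives 10000 nM. Among the measured compounds shown here, compound 1 therefore stands level with compound 2, the only other compound measured so far, and the two values sit within the usual scatter of repeated measurements.

Compound 3 (`COc1ccc(-c2cc3cccc(OC)c3nc2O)cc1`) has not yet been measured. It differs from compound 1 by a single change: methoxy in place of hydrogen on an aromatic carbon. Here, methoxy replaces hydrogen on an aromatic carbon of a six-membered aromatic ring of carbon only, para to a large group.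

For the measured compounds named here, no pair of measured compounds shows what this swap does in this assay, so there is no earlier step to use as a guide. Going by the values given here, the only anchor is compound 1 at 10000 nM, and no step beyond the scatter is expected in either direction. The estimated change is no change at the digits printed from compound 1 to compound 3 (within the scatter). For compound 3, the expected half-maximal inhibitory concentration is 10000 nM, with an estimated range of 4000 nM to 25000 nM.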

Compound 3, half-maximal inhibitory concentration: 10000 nM
Compound 3: middle estimate and measured number agree at the digits printed, within the range that was stated.
By their numbers in this assay, from the lowest: compounds 1, 2 and 3 (each within the scatter of the next).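

Read in this assay, placing methoxy on an aromatic carbon of the six-membered aromatic ring of carbon only, para to a large group, gives no change at the digits printed from compound 1 to compound 3 (within the scatter). Among the compounds shown here, this is the first direct reading of this swap: on the core of compound 1, this added methoxy leaves the number within the scatter, so this single change gives no sign of a gain or a loss in this assay. Nothing measured here accounts for this flat result.

One swap at one position cannot show whether a different group there, such as an amine, a carboxylic acid or a longer chain, would separate from compound 1 at 10000 nM. It also leaves open whether methoxy would give the same reading at other places on the shared core, or whether any change to that core could bring the number clearly beyond the scatter.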